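A few compounds are considered here, and "the series" means these few. Any claim that something is new, unique, unknown or untested is made for them only; others in the source may bear on it.

Compound 2 `Fc1ccc(-c2cn3ccnc3c(-c3ccc4ncn(C5CCCCC5)c4c3)n2)cc1` gives 19.5% in a functional assay on MDA-MB-468 cells (Homo sapiens) for inhibition, read by sulforhodamine B assay, with a stated time of 48 h, tested at 10 uM (a higher number here means more inhibition at the concentration tested (going by the name of the read-out), a lower number less inhibition), and compound 1 `c1ccc2c(-c3cn4ccnc4c(-c4ccc5ncn(C6CCCCC6)c5c4)n3)cccc2c1` gives 10.4%; the step of a number 9.1 percentage points higher from compound 1 to compound 2 (within the scatter) lies within the scatter, so compound 2 stands level with compound 1 on the numbers shown. Compound 3 `c1cn2cc(-c3ccsc3)nc(-c3ccc4ncn(C5CCCCC5)c4c3)c2n1` differs from compound 2 by thiophen-3-yl in place of 4-fluorophenyl on an aromatic carbon. Among the measured compounds shown here, the only measured step at that same position, a number 9.1 percentage points higher from compound 1 to compound 2 (within the scatter), was within the scatter, so no shift beyond the scatter is expected for this assay; the expected step is a number 4.5 percentage points lower from compound 2 to compound 3 (within the scatter). Compound 3 is therefore estimated at 15% in this assay, in the range 3% to 35%.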

Compound 3, a percentage reported as inhibition, at one concentration (the size of the read-out at that concentration, not a potency) in the MDA-MB-468 assay: 21.8%
Compound 3: middle estimate off by 6.8 percentage points, on the low side; measured number inside the range.
By their numbers in the MDA-MB-468 assay, from the lowest: compounds 1, 2 and 3 (each within the scatter of the next, the first and the last beyond it).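

In the MDA-MB-468 assay compound 3 gives 21.8%, and thiophen-3-yl stands level with 4-fluorophenyl at this position (a number 2.3 percentage points higher from compound 2 to compound 3 (within the scatter)), while replacing the naphthalen-1-yl of compound 1 now gives a modest step beyond the scatter (a number 11.4 percentage points higher from compound 1 to compound 3 (beyond the scatter)). In a physicochemical assay for lipophilicity, using the shake flask method, in phosphate buffer, measured as octanol-water partition, with a stated time of 85 min, at pH 7.4 (on this read-out higher numbers stand for higher lipophilicity and lower numbers for lower lipophilicity), compound 2 gives 2.01 and compound 3 gives 1.81, and the change from 4-fluorophenyl to thiophen-3-yl also stays within the scatter (a number 0.20 log units lower from compound 2 to compound 3 (within the scatter)). No evidence is available to explain these results.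

On these data alone, all three groups at this position are aromatic rings, so the effect of an amine, a morpholine or a carboxylic acid there remains open.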